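A few compounds are considered here, and "the series" means these few. Any claim that something is new, unique, unknown or untested is made for them only; others in the source may bear on it.

Working notes on the series. In a functional assay on HepG2 cells (Homo sapiens) for cytotoxicity, read by MTT assay, with a stated time of 24 h (on this read-out lower numbers stand for stronger inhibition and higher numbers for weaker inhibition), compound 1 `O=C1/C(=C/c2cccnc2)CN(S(=O)(=O)c2ccccc2)C/C1=C\c1ccccc1C(F)(F)F` gives 5370 nM and compound 2 `Cc1ccc(S(=O)(=O)N2C/C(=C\c3cccnc3)C(=O)/C(=C/c3ccccc3C(F)(F)F)C2)cc1` gives 2930 nM. Compound 2 therefore stands within the scatter of compound 1, and the two values do not separate the pair. The next member is compound 3 `O=C1/C(=C/c2cccnc2)CN(S(=O)(=O)c2ccc([N+](=O)[O-])cc2)C/C1=C\c1ccccc1C(F)(F)F`, which differs from compound 2 in the sulfonyl group, 4-methylphenyl to 4-nitrophenyl: nitro in place of methyl on an aromatic carbon. This places nitro in place of methyl on an aromatic carbon, para to a large group.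

Among the measured compounds shown here, only one measured step bears on this change, methyl in place of hydrogen on an aromatic carbon: a 1.8-fold lower number from compound 1 to compound 2 (0.26 log units; within the scatter). For the measured compounds named here, that step stays within the scatter, and no measured compound carries nitro, so the data give no direction for the new group. No shift beyond the scatter is therefore expected in this assay, though the uncertainty is wide. The estimated step is a 1.1-fold higher number from compound 2 to compound 3 (0.04 log units; within the scatter). The expected value for compound 3 is 3200 nM. The estimated range for compound 3 runs from 1300 nM to 8000 nM.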

Compound 3, half-maximal inhibitory concentration: 9370 nM
Compound 3: the middle estimate sits 2.9-fold (0.47 log units) below what was measured; measured number outside the range, above it.
By their numbers in this assay, from the lowest: compounds 2, 1 and 3 (each within the scatter of the next, the first and the last beyond it).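

Among the compounds shown here, at the aromatic carbon para to a large group, the change from methyl to nitro gives the first step beyond the scatter in this assay (a 3.2-fold higher number from compound 2 to compound 3 (0.50 log units; beyond the scatter)), though the step is modest. The comparison with hydrogen qualifies this result: the step to nitro (a 1.7-fold higher number from compound 1 to compound 3 (0.24 log units; within the scatter)) lies within the scatter, as does the earlier step to methyl, so only the methyl and nitro compounds separate, while compound 1 separates from neither. This place on the sulfonyl aryl group can therefore shift the read-out beyond the scatter, but nothing available bears on the reason for the step.

With only hydrogen, methyl and nitro at this place, three compounds cannot show whether the values follow any ordering of substituents, and a methoxy group, an amine or a carboxylic acid there could test this. As far as these compounds go, it also remains open whether the difference between 4-methylphenyl and 4-nitrophenyl would hold with other groups on the shared core, or whether it reflects anything more specific than cytotoxicity in this single cell line.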